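Azepanyl for thiophenyl on the shared core

The source may hold more compounds than are shown below. What is called first, only, known or untested is meant among the compounds shown, and "the series" means these compounds.

Two compounds of the series have been run in a functional assay on cells for antagonist activity at prostaglandin E2 receptor EP1 subtype (Rattus norvegicus), read by fluorescence and calcium flux, with a stated time of 60 s; a higher number here means a weaker inhibitor, a lower number a stronger inhibitor. Compound 1 `CSc1ccc2c(Cc3cccc(C(=O)O)n3)c(-c3ccccc3)nn2c1` gives 87 nM and compound 2 `O=C(O)c1cccc(Cc2c(-c3ccsc3)nn3cc(Cl)ccc23)n1` gives 110 nM; the two numbers lie within the usual scatter of each other, so they cannot be separated, and compound 2 is simply one of two very similar results. Going by the values given here, no pair of measured compounds differs in a single place, so no measured step exists to guide the next move.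

Compound 3 `O=C(O)c1cccc(Cc2c(N3CCCCCC3)nn3cc(Cl)ccc23)n1` is the next compound to be tested in this assay. It differs from compound 2 in one place: azepan-1-yl in place of thiophen-3-yl on an aromatic carbon. The aromatic group of compound 2 is exchanged for a non-aromatic ring of seven atoms, a change of a kind not covered by anything measured so far, and both measured numbers come from compounds that carry an aromatic ring at this place.

For compound 3 the step of a 2.7-fold higher number from compound 2 to compound 3 (0.44 log units; beyond the scatter) is estimated as a moderate move toward a higher number, beyond the scatter but with wide uncertainty. The value expected for compound 3 is 300 nM, within a range from 80 nM to 1500 nM.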

Compound 3, half-maximal inhibitory concentration: 1400 nM
Compound 3: middle estimate off by 4.7-fold (0.67 log units), on the low side; the range from low to high includes it.
By their numbers in this assay, from the lowest: compounds 1 and 2 (each within the scatter of the next); then compound 3.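

In this assay, going by these compounds alone, this position proves sensitive to the group it carries: a 13-fold higher number from compound 2 to compound 3 (1.10 log units; beyond the scatter) is a large move toward weaker inhibition, and it is the first reading here for a non-aromatic ring on this aromatic carbon. The exchange of thiophen-3-yl for azepan-1-yl changes several things at once, since a five-membered aromatic ring with a sulfur atom gives way to a seven-membered non-aromatic ring with a nitrogen atom, so this single step does not show which of these differences matters. Nothing measured here gives a reason for the step.

Still open, going by these compounds, is whether a smaller non-aromatic ring such as piperidin-1-yl or pyrrolidin-1-yl would give a number closer to that of compound 2, and whether cyclohexyl, which is attached through carbon rather than nitrogen, would behave like azepan-1-yl. An open-chain amine such as diethylamino at this place would also help separate the effect of the attached nitrogen from that of the ring itself.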